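Removing One Methoxy Group from Compound 2

The compounds below may be only part of what the source reports. "The series", "measured", "known", "first", "only" and "open" are said of these compounds alone.

Measured in a functional assay (Homo sapiens) for inhibition; on this read-out higher numbers stand for weaker inhibition and lower numbers for stronger inhibition:
Compound 1 `COc1ccc(/C=C/C(=O)c2ccccc2Br)c(OC)c1`: 35000 nM
Compound 2 `COc1cc(OC)c(OC)cc1/C=C/C(=O)c1ccc(O)cc1`: 28000 nM

The two measured compounds lie within the scatter of each other, so compound 2 stands level with compound 1 on these numbers. Compound 3 `COc1ccc(/C=C/C(=O)c2ccc(O)cc2)c(OC)c1` has not yet been measured. It departs from compound 2 by a single change, hydrogen in place of methoxy on an aromatic carbon. Among the measured compounds shown here, no measured pair shows this change on its own, so the expectation rests on thin evidence. Compound 1, which also lacks that methoxy but differs elsewhere, gives 35000 nM. On that basis, no step beyond the scatter is expected in this assay. The expected step of a 1.1-fold higher number from compound 2 to compound 3 (0.03 log units; within the scatter) is therefore small, with no firm direction. The estimated value for compound 3 is 30000 nM, with an expected range from 10000 nM to 80000 nM.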

Compound 3, half-maximal inhibitory concentration: 71000 nM
Compound 3: the middle estimate sits 2.4-fold (0.37 log units) below what was measured; measured number inside the range.
By their numbers in this assay, from the lowest: compounds 2 and 1 (each within the scatter of the next); then compound 3.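

In this assay, among the compounds shown here, this is the first reading of this methoxy group on its own: hydrogen in its place gives a 2.5-fold higher number from compound 2 to compound 3 (0.40 log units; beyond the scatter) and so weakens inhibition modestly, which shows that this position is not indifferent to the change. Compound 3 also separates from compound 1, since 4-hydroxyphenyl in place of 2-bromophenyl on a carbonyl carbon gives a 2.0-fold higher number from compound 1 to compound 3 (0.31 log units; beyond the scatter) in this comparison. Compound 1 and compound 2, by contrast, stand level. The data shown offer nothing that explains why removing the methoxy group weakens inhibition and the step stands as an observation only.

Whether methoxy itself matters at this carbon stays open, as the compounds shown include no ethoxy group, fluorine atom or hydroxyl group there. Also open, from the compounds shown here alone, is whether the step would be the same size with 2-bromophenyl on the carbonyl carbon.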